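Exchanging the cinnamyl arm of compound 1 for a short polar chain

The compounds below may be only part of what the source reports. "The series", "measured", "known", "first", "only" and "open" are said of these compounds alone.

This account follows one change made to compound 1 `Nc1nc(O)c2c(n1)n(C1OC(CO)[C@@H](O)[C@H]1O)c(=O)n2C/C=C/c1ccccc1` and weighs what it may do in a functional assay on the whole organism (B cells) with Mus musculus as the target; on this read-out lower numbers stand for smaller maximal responses and higher numbers for larger maximal responses. Of the compounds shown here, three have been measured. Compound 1 reaches 73% in this assay. Compound 2 `C=CCn1c(=S)n(C2OC(COCc3ccccc3)[C@H]3OC(C)(C)O[C@@H]23)c2nc(N)nc(O)c21` reaches 77% in this assay, a number within the usual scatter of that of compound 1, so no order between the two can be read. Compound 3 `C=CCn1c(=O)n([C@@H](CO)OC(CO)CO)c2nc(N)nc(O)c21` gives 0% in this assay, far below compound 1 and beyond the scatter. Compound 1 therefore stands in the upper pair of the three, with compound 3 alone at the bottom.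

Compound 4 `NCC(O)Cn1c(=O)n(C2OC(CO)[C@@H](O)[C@H]2O)c2nc(N)nc(O)c21` has not yet been measured. It differs from compound 1 in one place: 2-amino-1-hydroxyethyl in place of 2-phenylethenyl on a saturated chain carbon bound to an aromatic nitrogen. Among the compounds with values here, no measured pair isolates this change, so its size must be guessed. Within the data shown here, because compound 3, the one compound without a larger group on the aromatic nitrogen, gives 0% in this assay, a drop beyond the scatter is expected for compound 4, with the step of a number 33 percentage points lower from compound 1 to compound 4 (beyond the scatter) estimated. Compound 4 is expected to reach about 40% in this assay, within a range from 5% to 80%.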

Compound 4, largest response reached (reported as maximal response), in percent of the reference or control that the assay uses: 110%
Beside the measured number, compound 4's estimate is 70 percentage points below it, outside the stated range (above it).
By their numbers in this assay, from the lowest: compound 3; then compounds 1 and 2 (each within the scatter of the next); then compound 4.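

The exchange of 2-phenylethenyl for 2-amino-1-hydroxyethyl on a saturated chain carbon bound to an aromatic nitrogen gives, in this assay, a number 37 percentage points higher from compound 1 to compound 4 (beyond the scatter). Within the data shown here, this is the first pair here that differs in one place, and it shows that, on the core of compound 1, the arm at this position needs neither a six-membered aromatic ring nor a double bond outside aromatic rings to give a large maximal response. Nothing at hand bears on why the response rises with this change.

The compounds shown leave open whether the amine, the hydroxyl or both account for the step, which a chain carrying only one of the two would separate. They also leave open how a longer chain or a carboxylic acid in place of the amine would read in this assay.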